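Bromo to Nitro on Another Aromatic Ring

The source may hold more compounds than are shown below. What is called first, only, known or untested is meant among the compounds shown, and "the series" means these compounds.

Among the compounds with values here, in a functional assay on MCF7 cells (Homo sapiens) for inhibition, read by sulforhodamine B assay, with a stated time of 48 h (a lower number here means a stronger inhibitor of growth, a higher number a weaker inhibitor of growth), compound 1 (`N#CCC1=C(C#N)CC(c2ccc(Br)cc2)=C(CC(=O)c2ccc(Br)cc2)O1`) gives 12000 nM, the highest of the three numbers measured so far. Compound 2 (`N#CCC1=C(C#N)CC(c2ccc([N+](=O)[O-])cc2)=C(CC(=O)c2ccc(Br)cc2)O1`) gives 4900 nM. Compound 3 (`N#CCC1=NN=C(c2ccc([N+](=O)[O-])cc2)CO1`) gives 1 nM, far lower, but its structure does not share the core of compound 1 and it differs in more than one place, so it offers no guide to a single exchange.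

The step of interest leads to compound 4 (`N#CCC1=C(C#N)CC(c2ccc(Br)cc2)=C(CC(=O)c2ccc([N+](=O)[O-])cc2)O1`), which has not yet been measured in this assay. The change is nitro in place of bromo on an aromatic carbon, 4-bromophenyl to 4-nitrophenyl.

Within the data shown here, the only measured step with the same exchange is a 2.4-fold lower number from compound 1 to compound 2 (0.39 log units; beyond the scatter). Among the measured compounds shown here, that exchange was made on a different aromatic ring from the one altered in compound 4, so it offers only limited support. Even so, a step of similar modest size towards a lower number is expected, although a step within the scatter would not be surprising.

The expected change is a 2.2-fold lower number from compound 1 to compound 4 (0.34 log units; beyond the scatter). For compound 4 the estimated value is 5500 nM, with an expected range from 2000 nM to 14000 nM.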

Compound 4, concentration for 50% growth inhibition: 90 nM
For compound 4 the middle estimate is 61-fold (1.79 log units) above the measured one, outside the stated range (below it).
By their numbers in this assay, from the lowest: compound 3; then compound 4; then compound 2; then compound 1.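

In this assay the exchange gives a 130-fold lower number from compound 1 to compound 4 (2.12 log units; beyond the scatter) on the aromatic ring altered in compound 4, whereas on the other aromatic ring it gives only a 2.4-fold lower number from compound 1 to compound 2 (0.39 log units; beyond the scatter) and so a far smaller change. Within the data shown here, the size of this step therefore depends on which of the two rings of the shared core carries the nitro group, something the earlier compounds could not show with only one such exchange among them. Nothing at hand accounts for the difference between the two rings.

On these data alone, it remains open whether the large step belongs to nitro itself or would also appear with another group at this position, such as an amine or a carboxylic acid in place of the bromo. The compounds shown also leave open what a nitro group on both aromatic rings of the shared core would give, and whether the two exchanges would add up or not.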